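From compound 3 to compound 4: a larger group on the carbonyl

The source may report more compounds than this note shows. Statements on the series, on what has been measured and on what is new or still open speak of the compounds shown alone.

Compound 1 `CC(C)n1ncc2c(C(=O)Nc3c(F)cccc3F)cc(-c3cccs3)nc21`: > 200000 nM (a limit of the assay)
Compound 2 `CC(C)n1ncc2c(C(=O)Nc3ncccn3)cc(-c3cccs3)nc21`: 75000 nM
Compound 3 `CC(C)n1ncc2c(C(=O)Nc3ccncc3)cc(-c3cccs3)nc21`: 6300 nM

In an ADME assay on LLC-MK2 cells (Macaca mulatta) for cytotoxicity, read by spectrophotometry and crystal violet staining, with a stated time of 4 days (a higher number here means that more compound is tolerated, a lower number that less compound is tolerated), compound 3 stands lowest of the three at 6300 nM, and the nearest number belongs to compound 2, with a 12-fold lower number from compound 2 to compound 3 (1.08 log units; beyond the scatter). Compound 4 `CC(C)n1ncc2c(C(=O)N3CCc4cccnc43)cc(-c3cccs3)nc21` differs from compound 3 in one place, on a carbonyl carbon: a group of 9 heavy atoms (7 carbon, 2 nitrogen; one five-membered non-aromatic ring with 1 hetero atom, one six-membered aromatic ring with 1 hetero atom) in place of a group of 7 heavy atoms (5 carbon, 2 nitrogen; one six-membered aromatic ring with 1 hetero atom), on a carbonyl carbon. The (pyridin-4-yl)amino group leaves, and the group that enters has one five-membered non-aromatic ring and one six-membered aromatic ring. Among the measured compounds shown here, two measured steps bear on this change, and both are large. Compound 1 lies further from the pyridin-4-yl group, with an at least 31-fold lower number from compound 1 to compound 3 (1.50 log units; beyond the scatter). For the measured compounds named here, neither that step nor the one from compound 2 covers the entering group, so only a moderate move towards a higher number is expected. The expected size is a 4.8-fold higher number from compound 3 to compound 4 (0.68 log units; beyond the scatter), and this is an uncertain estimate. For compound 4 the estimated value is 30000 nM, with an expected range from 7000 nM to 130000 nM.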

Compound 4, half-maximal cytotoxic concentration: 50000 nM
The estimate for compound 4 lay 1.7-fold (0.22 log units) below the measured number, and the stated range covers the measured number.
By their numbers in this assay, from the lowest: compound 3; then compounds 4 and 2 (each within the scatter of the next). At a limit, above all of these: compound 1.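

In this assay, the group with one five-membered non-aromatic ring and one six-membered aromatic ring gives a 7.9-fold higher number from compound 3 to compound 4 (0.90 log units; beyond the scatter), and unlike the groups of compounds 1, 2 and 3, it has 0 hydrogen-bond donors. The change thus shows that a group without that donor can stand on this carbonyl carbon, and a 1.5-fold lower number from compound 2 to compound 4 (0.18 log units; within the scatter) leaves compound 2 and compound 4 indistinguishable in this assay. The step of an at least 4.0-fold lower number from compound 1 to compound 4 (0.60 log units; beyond the scatter) starts from a limit of the assay, so it gives a bound and not a size: the limit of > 200000 nM in this assay, at which 1 of the 4 values shown sits.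

The compounds shown cannot separate the loss of the amide hydrogen from the addition of the second ring as the source of the step. On these data alone, how a simple piperidine or morpholine amide, or a methyl group on the amide nitrogen of compound 3, would read remains open.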